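Swapping a pyridine for a chlorophenyl on an inert amide

A few compounds are considered here, and "the series" means these few. Any claim that something is new, unique, unknown or untested is made for them only; others in the source may bear on it.

Three amides share one core and differ only in the group on the carbonyl carbon. Compound 1 `O=C(Nc1ccc(Cl)c(-c2nnc3c(Cl)cccn23)c1)c1ccc(F)cc1Cl` carries a 2-chloro-4-fluorophenyl there, compound 2 `O=C(Nc1ccc(Cl)c(-c2nnc3c(Cl)cccn23)c1)c1ccccn1` a pyridin-2-yl, and compound 3 `O=C(Nc1ccc(Cl)c(-c2nnc3c(Cl)cccn23)c1)c1cccnc1` a pyridin-3-yl. In a functional assay on MDA-MB-468 cells (Homo sapiens) for antiproliferative activity, read by MTT assay, with a stated time of 72 h (on this read-out lower numbers stand for stronger inhibition and higher numbers for weaker inhibition), compound 1 gives > 100000 nM, which is a limit of the assay. Compound 2 gives > 100000 nM, again a limit. Compound 3 gives > 100000 nM, also a limit, so compound 3 stands nowhere higher or lower than its two neighbours on the numbers shown. The steps a step that the two limits leave unreadable from compound 1 to compound 2, a step that the two limits leave unreadable from compound 1 to compound 3 and a step that the two limits leave unreadable from compound 2 to compound 3 cannot be sized. Compound 4 `O=C(Nc1ccc(Cl)c(-c2nnc3c(Cl)cccn23)c1)c1ccc(Cl)cc1` is the untested member: 4-chlorophenyl in place of pyridin-3-yl on a carbonyl carbon; cut one bond further out, the change reads (pyridin-3-yl)carbonyl to (4-chlorophenyl)carbonyl. Among the measured compounds shown here, all measured values sit at the limit (the limit of > 100000 nM in this assay, at which 3 of the 3 values shown sit), and no measured step bears readably on this change, so the step of a number no higher from compound 3 to compound 4 (the limit leaves the size open) is expected to be none beyond the scatter. Compound 4 is estimated at 100000 nM, within 30000 nM to 300000 nM, and is expected to be reported again only as a limit.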

Compound 4, half-maximal inhibitory concentration: > 100000 nM
Compound 4 ended at the assay's limit; the forecaster's own chance of this, stated with the estimate: 85%; the middle value sits exactly at the limit.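

Compound 4 ends at a limit, like compound 1, compound 2 and compound 3, so no step among these four compounds can be read: the limit of > 100000 nM in this assay, at which 4 of the 4 values shown sit. On these data alone, what stays open is whether any group on the carbonyl carbon gives a readable value in this assay on this shared core.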